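Working notes: aryl group change from compound 2 to compound 3

The source may report more compounds than this note shows. Statements on the series, on what has been measured and on what is new or still open speak of the compounds shown alone.

Measured compounds:
compound 1 `COc1ccc(/C=C/C(=O)c2cccc(-n3cc(-c4ccc(C)cc4)nn3)c2)cc1O`, 1700 nM
compound 2 `COc1ccc(/C=C/C(=O)c2cccc(-n3cc(-c4ccccc4C(F)(F)F)nn3)c2)cc1O`, 9120 nM

Compound 2 stands at the higher of the two numbers in a functional assay on RAW264.7 cells (Mus musculus) for inhibition, with a stated time of 4 days; on this read-out lower numbers stand for stronger inhibition and higher numbers for weaker inhibition. Among the measured compounds shown here, the one measured step, a 5.4-fold higher number from compound 1 to compound 2 (0.73 log units; beyond the scatter), is modest yet beyond the scatter, and it is the only step bearing on the change considered here. Compound 3 `COc1ccc(/C=C/C(=O)c2cccc(-n3cc(-c4cccc(Cl)c4)nn3)c2)cc1O` is not yet measured; it differs from compound 2 by 3-chlorophenyl in place of 2-(trifluoromethyl)phenyl on an aromatic carbon. The change removes the group that went with the higher number, and a partial return toward the lower number is expected. For compound 3 a step of a 3.0-fold lower number from compound 2 to compound 3 (0.48 log units; beyond the scatter) is expected. Compound 3 is estimated at 3000 nM, with a range from 1000 nM to 9000 nM.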

Compound 3, half-maximal inhibitory concentration: 6610 nM
Estimate against measurement, compound 3: 2.2-fold (0.34 log units) below, and the stated range covers the measured number.
By their numbers in this assay, from the lowest: compound 1; then compounds 3 and 2 (each within the scatter of the next).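

In this assay 3-chlorophenyl in place of 2-(trifluoromethyl)phenyl gives a 1.4-fold lower number from compound 2 to compound 3 (0.14 log units; within the scatter) and so compound 2 and compound 3 cannot be told apart at this place on the shared core. The other step is a 3.9-fold higher number from compound 1 to compound 3 (0.59 log units; beyond the scatter) and it shows that compound 1 with its 4-methylphenyl now stands apart from two different aryl groups instead of one. No measured evidence accounts for this difference.

As far as these compounds go, what an unsubstituted phenyl, or a phenyl bearing an amine or a carboxylic acid, would give here stays open. Also open, from the compounds shown here alone, is whether the methyl group itself or its place on the ring sets compound 1 apart.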